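Adding 4-(trifluoromethyl)benzyl to the amide of compound 2

The compounds below may be only part of what the source reports. "The series", "measured", "known", "first", "only" and "open" are said of these compounds alone.

Compound 1 `C=C[C@@](C)(/C=C/c1ccc(O)c(/C=C/C(=O)OCC)c1)CCC=C(C)C`: > 49000 nM (a limit)
Compound 2 `C=C[C@@](C)(/C=C/c1ccc(O)c(/C=C/C(N)=O)c1)CCC=C(C)C`: > 49000 nM (a limit)

In a functional assay on Jurkat cells (Homo sapiens) for cytotoxicity, with a stated time of 72 h (on this read-out lower numbers stand for an effect already at smaller amounts and higher numbers for an effect only at larger amounts of compound), compound 2 gives > 49000 nM, which is only a limit. Compound 1 shares it: the limit of > 49000 nM in this assay, at which 2 of the 2 values shown sit. Compound 3 `C=C[C@@](C)(/C=C/c1ccc(O)c(/C=C/C(=O)NCc2ccc(C(F)(F)F)cc2)c1)CCC=C(C)C` arises from compound 2 through one change: 4-(trifluoromethyl)benzyl in place of hydrogen on an amide-type nitrogen. Going by the values given here, the only measured step, a step that the two limits leave unreadable from compound 1 to compound 2, bears on this change but offers no size to carry over. A modest move toward lower numbers is expected, though on thin grounds, and the expected step is an at least 1.9-fold lower number from compound 2 to compound 3 (0.29 log units; that floor lies within the scatter). For compound 3 the estimated value is 25000 nM, with an expected range of 6000 nM to 60000 nM.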

Compound 3, half-maximal effective concentration: > 49000 nM
Compound 3: a limit, no number (the forecaster's own chance of this, stated with the estimate: 45%); middle value at least 1.9-fold (0.29 log units) away from the limit.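

Compound 3 also sits at a limit rather than a number, so the steps linking compound 1, compound 2 and compound 3 cannot be read: the limit of > 49000 nM in this assay, at which 3 of the 3 values shown sit. What the compounds shown leave open is whether changing the group on the amide nitrogen affects the result in this assay at all.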